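Piperidine to sulfur-containing ring on the shared core

The source may report more compounds than this note shows. Statements on the series, on what has been measured and on what is new or still open speak of the compounds shown alone.

Measured so far:
compound 1, `N[C@H]1CC[C@H](Nc2c(C(=O)NCc3ccc(F)cc3)nc(N3CCCCC3)c3cccnc23)CC1`: 8000 nM
compound 2, `C[C@@H](CO)Nc1nc(C(=O)NCc2ccc(F)cc2)c(O)c2ncccc12`: "not determined" (no result reported)
compound 3, `COC(=O)c1nc(Br)c2cccnc2c1N[C@H]1CC[C@H](N)CC1`: "not determined" (no result reported)

Among the measured compounds shown here, in a functional assay on HCT-116 cells (Homo sapiens) for cytotoxicity, read by MTT assay, with a stated time of 72 h (on this read-out lower numbers stand for stronger inhibition and higher numbers for weaker inhibition), compound 1 gives 8000 nM, which is the only number in the set. For compound 2 the entry in this assay is "not determined" (no result reported), and for compound 3 it is likewise "not determined" (no result reported); neither supplies a reference point, so compound 1 stands alone and cannot be ranked against anything.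

The unmeasured compound 4, `N[C@H]1CC[C@H](Nc2c(C(=O)NCc3ccc(F)cc3)nc(N3CCCCS3(=O)=O)c3cccnc23)CC1`, keeps the core of compound 1 with the (4-fluorobenzyl)carbamoyl group and the (4-aminocyclohexyl)amino group in place and differs at one aromatic carbon only: a group of 8 heavy atoms (4 carbon, 1 nitrogen, 2 oxygen, 1 sulfur; one six-membered non-aromatic ring with 2 hetero atoms) in place of a group of 6 heavy atoms (5 carbon, 1 nitrogen; one six-membered non-aromatic ring with 1 hetero atom), on an aromatic carbon. The piperidin-1-yl group leaves, and a six-membered non-aromatic ring with 2 hetero atoms, carrying 2 hydrogen-bond acceptors and 2 double bonds outside aromatic rings, enters.

For the measured compounds named here, no step between measured compounds exists to calibrate this exchange, so the expectation rests on compound 1 alone. The step from compound 1 to compound 4 is expected to be small, within the scatter or drifting slightly toward weaker inhibition, as a 1.3-fold higher number from compound 1 to compound 4 (0.10 log units; within the scatter). On that basis compound 4 is estimated at 10000 nM in this assay, within a range from 3000 nM to 40000 nM.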

Compound 4, half-maximal inhibitory concentration: > 10000 nM
Compound 4: no number, only a limit (the forecaster's own chance of this, stated with the estimate: 20%); the middle value lies on the limit itself.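

In this assay compound 4 gives > 10000 nM, which is a limit of the assay and not a number. Among the compounds shown here, putting the sulfur-containing six-membered ring in place of piperidin-1-yl, on the aromatic carbon next to the ring nitrogen, gives the first step at this position, an at least 1.2-fold higher number from compound 1 to compound 4 (0.09 log units; that floor lies within the scatter), so this exchange brings no stronger inhibition than compound 1 shows, while the true size of the step stays unread. This step is only a floor, and the reading that sets it is: the limit of > 10000 nM in this assay, at which 1 of the 4 values shown sits.

The compounds shown leave open how a morpholin-4-yl ring, a dimethylamino group or a carboxylic acid on this aromatic carbon would read in this assay. Also open, as far as these compounds go, are how far the value of compound 4 lies past its limit, and whether this exchange would read the same with a different group in place of the (4-aminocyclohexyl)amino group or the (4-fluorobenzyl)carbamoyl group.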